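Phenyl for pentan-3-yl: a solubility estimate at low pH

The source may hold more compounds than are shown below. What is called first, only, known or untested is meant among the compounds shown, and "the series" means these compounds.

Measured so far:
- compound 1 `CCC(CC)C(/C=C1\OC(=O)NC1=O)c1ccc(-c2ccc3cccc(F)c3c2)[nH]c1=O`: 3680 nM
- compound 2 `CC(C)C(CC1NC(=O)NC1=O)c1ccc(-c2ccc3cccc(F)c3c2)[nH]c1=O`: 13000 nM

In a physicochemical assay for solubility, measured as kinetic solubility, at pH 2 (a lower number here means a less soluble compound, a higher number a more soluble compound), compound 1 gives 3680 nM, the lowest of the two numbers recorded; compound 2 gives 13000 nM, a gap beyond the scatter. Compound 3 `O=C1NC(=O)/C(=C/C(c2ccccc2)c2ccc(-c3ccc4cccc(F)c4c3)[nH]c2=O)O1` has not yet been measured. It differs from compound 1 in one place: phenyl in place of pentan-3-yl on a saturated chain carbon bound to an aromatic carbon and a double-bonded chain carbon. Within the data shown here, no measured pair shows the effect of such a change, so the direction is uncertain. The expected step is a 1.2-fold lower number from compound 1 to compound 3 (0.09 log units; within the scatter). Compound 3 is estimated at 3000 nM, within 1000 nM to 9000 nM.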

Compound 3, solubility: 15400 nM
Estimate against measurement, compound 3: 5.1-fold (0.71 log units) below; measured number outside the range, above it.
By their numbers in this assay, from the lowest: compound 1; then compounds 2 and 3 (each within the scatter of the next).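

In this assay, putting phenyl in place of pentan-3-yl on a saturated chain carbon bound to an aromatic carbon and a double-bonded chain carbon gives a 4.2-fold higher number from compound 1 to compound 3 (0.62 log units; beyond the scatter). Among these compounds, this is the first single-change pair at this position, and it shows that the read-out responds to the group placed there, with the aromatic ring on the higher side. No measurement at hand explains the rise.

This single pair cannot say whether other groups on this carbon, such as an amine, a carboxylic acid or a longer chain, would move the number the same way. It also leaves open whether the step would hold on a core other than that of compound 1.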